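The source may hold more compounds than are shown below. What is called first, only, known or untested is meant among the compounds shown, and "the series" means these compounds.

Values measured in an ADME assay on Huh7.5.1 cells (Homo sapiens) for cytotoxicity, read by ATP content, with a stated time of 48 h; on this read-out higher numbers stand for lower toxicity in this test and lower numbers for higher toxicity in this test:

- Compound 1 `Cc1oc(-c2c(Cl)cccc2Cl)nc1CN1CCC(C(=O)NCCCN2C[C@H](C)C[C@H](C)C2)CC1`: 13200 nM
- Compound 2 `Cc1oc(-c2c(Cl)cccc2Br)nc1CN1CCC(C(=O)NCCCN2C[C@H](C)C[C@H](C)C2)CC1`: 12200 nM
- Compound 3 `Cc1ccc(-c2nc(CN3CCC(C(=O)NCCCN4C[C@H](C)C[C@H](C)C4)CC3)c(C)o2)cc1C`: 6910 nM

All three compounds share one core and differ only in the aromatic group on it. Compound 3, at 6910 nM, lies within the usual scatter of both other compounds: the steps are a 1.9-fold lower number from compound 1 to compound 3 (0.28 log units; within the scatter) and a 1.8-fold lower number from compound 2 to compound 3 (0.25 log units; within the scatter).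

The next compound to be tested is compound 4 `Cc1ccc(-c2nc(CN3CCC(C(=O)NCCCN4C[C@H](C)C[C@H](C)C4)CC3)c(C)o2)c(C)c1`. It keeps the atoms of compound 3 but joins them differently, with 2,4-dimethylphenyl in place of 3,4-dimethylphenyl on an aromatic carbon.

Within the data shown here, no measured pair moves a methyl group around this aromatic ring, so the evidence is indirect. The closest guides are the two steps that reached compound 3 by replacing a whole halogen-bearing aromatic group, and both stayed within the scatter. The swap of one halogen for another, a 1.1-fold lower number from compound 1 to compound 2 (0.03 log units; within the scatter), was smaller still. In this small set, then, changes to this group have barely moved the number in this assay, and a shift of one methyl group gives no reason to expect more.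

The expected change is no step beyond the scatter, in either direction, and the estimated step is a 1.2-fold higher number from compound 3 to compound 4 (0.06 log units; within the scatter). For compound 4 the estimated value is 8000 nM, with an expected range of 4500 nM to 14000 nM.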

Compound 4, half-maximal cytotoxic concentration: 4110 nM
Beside the measured number, compound 4's estimate is 1.9-fold (0.29 log units) above it; the whole stated range lies above it.
By their numbers in this assay, from the lowest: compounds 4, 3, 2 and 1 (each within the scatter of the next, the first and the last beyond it).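

Within this assay, moving a methyl group around the ring, with 2,4-dimethylphenyl in place of 3,4-dimethylphenyl, leaves the two compounds inseparable (a 1.7-fold lower number from compound 3 to compound 4 (0.23 log units; within the scatter)). The halogen-bearing compounds, however, now differ measurably from a dimethylphenyl compound, which compound 3 alone did not show: both (a 3.0-fold lower number from compound 2 to compound 4 (0.47 log units; beyond the scatter)) and (a 3.2-fold lower number from compound 1 to compound 4 (0.51 log units; beyond the scatter)) pass beyond the scatter, though only modestly, and they point to higher toxicity in this test for compound 4. So this position can shift the number when the whole aromatic group is exchanged, yet this shift appears only for the 2,4-dimethylphenyl compound, and no supporting measurement accounts for it.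

The compounds shown leave open whether the gap follows from the methyl arrangement or from the absence of the halogens, and a phenyl ring bearing a single methyl group or one chlorine would help separate those two readings. They also leave open how far the number can move at this position when the ring carries something quite different, such as an amine or a carboxylic acid.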